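The source may hold more compounds than are shown below. What is called first, only, known or untested is meant among the compounds shown, and "the series" means these compounds.

In a physicochemical assay for lipophilicity (a lower number here means a more polar compound, a higher number a more lipophilic compound), compound 2 `CC(C)(C)C#Cc1cc(N(C(=O)[C@H]2CC[C@H](C)CC2)[C@H]2CC[C@H](OC3CCOCC3)CC2)c(C(=O)O)s1` gives 2.4, which lies within the scatter of compound 1 `CC(C)(C)C#Cc1cc(N(C(=O)[C@H]2CC[C@H](C)CC2)[C@H]2CC[C@H](OC3COC3)CC2)c(C(=O)O)s1` at 2.6. Compound 3 `CC(C)(C)C#Cc1cc(N(C(=O)[C@H]2CC[C@H](C)CC2)[C@H]2CC[C@H](Oc3ccc(=O)[nH]n3)CC2)c(C(=O)O)s1` shares its core with compound 2 but has not yet been measured. The structural change is a group of 7 heavy atoms (4 carbon, 2 nitrogen, 1 oxygen; one six-membered aromatic ring with 2 hetero atoms) in place of a group of 6 heavy atoms (5 carbon, 1 oxygen; one six-membered non-aromatic ring with 1 hetero atom), on an oxygen on a saturated carbon. For the measured compounds named here, only one measured step bears on this change, the swap of oxetan-3-yl for oxan-4-yl on the same oxygen, which gave a number 0.20 log units lower from compound 1 to compound 2 (within the scatter). That step offers only a loose guide, since both of its groups are non-aromatic rings. Going by the values given here, no measured compound carries a six-membered aromatic ring on this oxygen, and no measured step shows what such a ring does to the number. The entering group has a hydrogen-bond donor and the leaving group has none, so the expectation leans modestly towards a lower number, with real uncertainty about the size. The estimated step is a number 0.30 log units lower from compound 2 to compound 3 (within the scatter). For compound 3 the expected value is 2.1, with an estimated range from 1.5 to 2.7.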

Compound 3, distribution coefficient: 2
Beside the measured number, compound 3's estimate is 0.10 log units above it; the measured number falls inside the stated range.
By their numbers in this assay, from the lowest: compound 3; then compounds 2 and 1 (each within the scatter of the next).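

In this assay, putting the new aromatic ring on an oxygen on a saturated carbon gives a number 0.40 log units lower from compound 2 to compound 3 (beyond the scatter), and set against the oxetan-3-yl group, the same ring gives a number 0.60 log units lower from compound 1 to compound 3 (beyond the scatter). For the compounds shown here, the earlier step, between two non-aromatic rings, stayed within the scatter, so this is the first change at this position that clearly moves the number, and compound 3 now stands lowest of the three. The entering group differs from oxan-4-yl in several ways at once, with an aromatic ring, nitrogen atoms and a hydrogen-bond donor, and nothing available ties the step to any one of these features.

Still open, from the compounds shown here alone, is how much of the step belongs to the aromatic ring itself and how much to the atoms it carries, a question that a plain phenyl ring on the same oxygen would help to separate. Also open is where an open-chain group, such as a methoxyethyl chain, would fall on this oxygen compared with the rings shown here.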